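This account rests on a few compounds, and the source may have more. Where it says the series, first, only, none or still open, it means among the compounds named here.

Measured so far in an ADME assay on cells (Macrophage, Mus musculus) for cytotoxicity, read by MTT assay, with a stated time of 72 h; on this read-out lower numbers stand for higher toxicity in this test and higher numbers for lower toxicity in this test:

compound 1 `CCN(CC)S(=O)(=O)c1cc(/C=C/C(=O)c2ccccc2)ccc1OC` — 57800 nM
compound 2 `COc1ccc(/C=C/C(=O)c2ccccc2)cc1S(=O)(=O)N1CCOCC1` — 57800 nM
compound 3 `COc1ccc(/C=C/C(=O)c2ccccc2)cc1S(=O)(=O)Nc1ccccc1` — 57800 nM

Compound 1 stands level with compounds 2 and 3 at the digits given. The step of no change at the digits printed from compound 1 to compound 2 (within the scatter) and the step of no change at the digits printed from compound 1 to compound 3 (within the scatter) both stay within the scatter, as does the step of no change at the digits printed from compound 2 to compound 3 (within the scatter). Three different groups on the sulfonyl sulfur, with the rest of the shared core unchanged, therefore give the same read-out in this assay.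

Compound 4 `COc1ccc(/C=C/C(=O)c2ccccc2)cc1S(=O)(=O)NCc1ccccc1` is not yet measured. Relative to compound 1 the change is benzylamino in place of diethylamino on a sulfonyl sulfur.

All three measured steps bear on this change, since each of them also swaps the group on the sulfonyl sulfur, and each was flat. The group entering in compound 4 shares a six-membered aromatic ring of carbon only with the anilino group of compound 3 and adds a hydrogen-bond donor, as the anilino group does; compound 3 gives 57800 nM. Within the data shown here, no step has moved beyond the scatter, so no step beyond the scatter is expected here either.

Compound 4 is therefore expected to give about 57800 nM, with a range from 29000 nM to 100000 nM. The expected step of no change at the digits printed from compound 1 to compound 4 (within the scatter) amounts to no change within the scatter.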

Compound 4, half-maximal cytotoxic concentration: 57800 nM
Beside the measured number, compound 4's estimate shows no gap at the digits printed; the measured number falls inside the stated range.
By their numbers in this assay, from the lowest: compounds 1, 2, 3 and 4 (each within the scatter of the next).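

In this assay, benzylamino, with 8 heavy atoms, one six-membered aromatic ring and 1 hydrogen-bond donor, replaces diethylamino, with 5 heavy atoms, no ring and 0 donors, and the result is no change at the digits printed from compound 1 to compound 4 (within the scatter). The series now also holds a change on the sulfonamide nitrogen itself, benzyl in place of phenyl, with the result no change at the digits printed from compound 3 to compound 4 (within the scatter), while the comparison with the ring amine gives no change at the digits printed from compound 2 to compound 4 (within the scatter); across the four compounds, the sulfonyl sulfur position has therefore taken open-chain, ring-bound, aryl and benzyl amine groups without a step beyond the scatter in this read-out. No measurement shown accounts for this flat behaviour.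

Still open, from the compounds shown here alone, is whether a longer chain on the sulfonamide nitrogen, such as phenethylamino, or a carboxylic acid or a primary amine carried on the benzyl ring would produce a step beyond the scatter in this assay. Going by these compounds, all four compounds also keep the methoxy group and the unsubstituted phenyl ketone of the shared core, so the response to changes at those sites remains unknown.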